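Compound 1 to Compound 3: Exchanging the Pyrazole for a Triazole

The source may hold more compounds than are shown below. What is called first, only, known or untested is meant among the compounds shown, and "the series" means these compounds.

Among the compounds with values here, in an ADME assay on microsomes from liver (Homo sapiens) for metabolic stability, read by LC-MS, using NADPH, with a stated time of 15 min, tested at 1 uM (on this read-out higher numbers stand for fast clearance and lower numbers for slow clearance), compound 1 `Cc1nn(CC(=O)N2CCN(c3sc(C(F)(F)F)nc3-c3nc4ccccc4[nH]3)C[C@H]2C)cc1CN(C)C` gives 37 mL.min-1.g-1, the only exact number so far. Compound 2 `Cc1nc(C)n(CC(=O)N2CCN(c3sc(C(F)(F)F)nc3-c3nc4ccc(C(C)(C)O)c(F)c4[nH]3)C[C@H]2C)n1` is reported only as a limit, < 10 mL.min-1.g-1. Compound 3 `Cc1nc(C)n(CC(=O)N2CCN(c3sc(C(F)(F)F)nc3-c3nc4ccccc4[nH]3)C[C@H]2C)n1` differs from compound 1 in one place, on a saturated chain carbon bound to a carbonyl carbon, where 3,5-dimethyl-1H-1,2,4-triazol-1-yl takes the place of 4-((dimethylamino)methyl)-3-methyl-1H-pyrazol-1-yl (3,5-dimethyl-1H-1,2,4-triazol-1-yl in place of 4-((dimethylamino)methyl)-3-methyl-1H-pyrazol-1-yl on a saturated chain carbon bound to a carbonyl carbon). Within the data shown here, no measured step yet shows what this exchange does, so no step beyond the usual scatter is expected a 1.9-fold lower number from compound 1 to compound 3 (0.27 log units; within the scatter). For compound 3, the estimated value in this assay is 20 mL.min-1.g-1, with an expected range of 10 mL.min-1.g-1 to 40 mL.min-1.g-1.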

Compound 3, intrinsic clearance in microsomes: 30 mL.min-1.g-1
Compound 3: the middle estimate sits 1.5-fold (0.18 log units) below what was measured; the range from low to high includes it.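

On a saturated chain carbon bound to a carbonyl carbon, 3,5-dimethyl-1H-1,2,4-triazol-1-yl in place of 4-((dimethylamino)methyl)-3-methyl-1H-pyrazol-1-yl gives a 1.2-fold lower number from compound 1 to compound 3 (0.09 log units; within the scatter) in this assay. At this position, the two groups cannot be told apart on this read-out, although one carries a (dimethylamino)methyl group and the other does not. No measurement shown gives a reason for this result. The compounds shown leave open whether another group at this place, such as a carboxylic acid or a pyridine, would shift intrinsic clearance in microsomes beyond the scatter.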